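This account rests on a few compounds, and the source may have more. Where it says the series, first, only, none or still open, it means among the compounds named here.

Compound 1 `CN(C)c1ccc(/C=C2/S/C(=N/c3ccccc3)N(Cc3ccncc3)C2=O)cc1`: 76300 nM
Compound 2 `CC(C)c1ccc(/C=C2/S/C(=N/c3ccccc3)N(Cc3ccncc3)C2=O)cc1`: 53300 nM

Both values come from a functional assay on MCF7 cells (Homo sapiens) for cytotoxicity, read by MTT assay, with a stated time of 48 h; a higher number here means a weaker inhibitor, a lower number a stronger inhibitor. Compound 2 has only compound 1 as a neighbour on these numbers, and the two cannot be ordered: a 1.4-fold lower number from compound 1 to compound 2 (0.16 log units; within the scatter). The next change leads to compound 3 `COc1cc(/C=C2/S/C(=N/c3ccccc3)N(Cc3ccncc3)C2=O)ccc1O` and is 4-hydroxy-3-methoxyphenyl in place of 4-isopropylphenyl on a double-bonded chain carbon bound to a double-bonded ring carbon, with 4-hydroxy-3-methoxyphenyl in place of 4-isopropylphenyl on a double-bonded chain carbon bound to a double-bonded ring carbon. Going by the values given here, compound 1 and compound 2 differ from compound 3 only in this group, so their single step is the one measured step that bears on the change. That step stayed within the scatter, and no step beyond the scatter is expected in this assay. This expectation rests on thin evidence. Among the compounds with values here, no measured compound carries a hydroxy or methoxy group, and one step cannot show how far this group may move the number, in either direction. The expected outcome is a 1.1-fold lower number from compound 2 to compound 3 (0.03 log units; within the scatter). For compound 3 the estimated value is 50000 nM, with an expected range of 20000 nM to 120000 nM.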

Compound 3, half-maximal inhibitory concentration: 28000 nM
Estimate against measurement, compound 3: 1.8-fold (0.25 log units) above; measured number inside the range.
By their numbers in this assay, from the lowest: compounds 3, 2 and 1 (each within the scatter of the next, the first and the last beyond it).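

In this assay, the place on a double-bonded chain carbon bound to a double-bonded ring carbon now gives its first step beyond the scatter: a 2.7-fold lower number from compound 1 to compound 3 (0.44 log units; beyond the scatter) with the entry of 4-hydroxy-3-methoxyphenyl, a modest step. Against 4-isopropylphenyl, the same group gives a 1.9-fold lower number from compound 2 to compound 3 (0.28 log units; within the scatter) and stays within the scatter, so compound 2 cannot be ordered against either of the other two, and only the two ends of this short series separate. No measurement at hand explains the difference between these groups.

The shown compounds leave open whether the hydroxy group or the methoxy group alone would give the same number at this place, since the two enter together; 4-hydroxyphenyl and 4-methoxyphenyl would separate them. Going by these compounds, it also remains open how a carboxylic acid or a primary amine on the same aromatic ring would read, and whether any change elsewhere on the shared core would move the number further than this modest step.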